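Fluoro Added to the Triazole Aryl Ring of Compound 3

This account rests on a few compounds, and the source may have more. Where it says the series, first, only, none or still open, it means among the compounds named here.

Compound 3, with the structure `C=C1C[C@]23C[C@@]1(O)CC[C@H]2c1cc(Br)c(O)c(C)c1[C@@H]3Cn1cc(-c2ccccc2)nn1`, carries a bromo and a phenyl on the shared core. In a functional assay on MCF7 cells (Homo sapiens) for cytotoxicity, read by MTT assay, with a stated time of 4 days (on this read-out higher numbers stand for weaker inhibition and lower numbers for stronger inhibition), compound 3 gives > 20000 nM, which is a limit of the assay rather than a number. Its neighbours sit the same way: compound 1 `C=C1C[C@]23C[C@@]1(O)CC[C@H]2c1cc(Br)c(O)c(C)c1[C@@H]3Cn1cc(-c2ccc(OC)cc2)nn1` gives > 20000 nM in this assay, a limit. Compound 2 `C=C1C[C@]23C[C@@]1(O)CC[C@H]2c1ccc(O)c(C)c1[C@@H]3Cn1cc(-c2ccccc2)nn1` gives > 20000 nM in this assay, again a limit. The step that the two limits leave unreadable from compound 1 to compound 3 and the step that the two limits leave unreadable from compound 2 to compound 3 therefore cannot be read in size, because of the limit of > 20000 nM in this assay, at which 3 of the 3 values shown sit.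

Compound 4 `C=C1C[C@]23C[C@@]1(O)CC[C@H]2c1cc(Br)c(O)c(C)c1[C@@H]3Cn1cc(-c2ccc(F)cc2)nn1` differs from compound 3 by fluoro in place of hydrogen on an aromatic carbon. Going by the values given here, no measured step touches this position, and the two steps that exist are unreadable, so no direction can be taken from them. Since compound 3 sits at the limit in this assay, the step that the limit leaves unreadable from compound 3 to compound 4 is expected to leave compound 4 at or beyond that same limit. Compound 4 is accordingly estimated at 30000 nM in this assay, within the range 15000 nM to 100000 nM.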

Compound 4, half-maximal inhibitory concentration: 19200 nM
The estimate for compound 4 lay 1.6-fold (0.19 log units) above the measured number; low and high end bracket the measured number.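

In this assay, going by these compounds alone, compound 4 gives 19200 nM, the first number in this set rather than a limit, so a fluoro on this aromatic carbon is compatible with a measurable read-out. The change from phenyl to 4-fluorophenyl is an at least 1.0-fold lower number from compound 3 to compound 4 (0.01 log units; that floor lies within the scatter), and the change from methoxy to fluoro at the same place is an at least 1.0-fold lower number from compound 1 to compound 4 (0.01 log units; that floor lies within the scatter). Both are only floors, and neither these steps nor the earlier ones can be read in full size because one or both ends of each are limits: the limit of > 20000 nM in this assay, at which 3 of the 4 values shown sit.

From the compounds shown here alone, it remains open whether an amine or a carboxylic acid on this aromatic carbon would lower the number further. Also open, going by these compounds, is what the bromo contributes when the 4-fluorophenyl group is present.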